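The source may report more compounds than this note shows. Statements on the series, on what has been measured and on what is new or still open speak of the compounds shown alone.

The measured compounds:
compound 1, `O=C(CCCCCCc1ccccc1)c1ncc(-c2ccccc2F)o1` — > 10000 nM
compound 2, `O=C(CCCCCCc1ccccc1)c1ncc(-c2ccc(F)cc2)o1` — > 10000 nM

In an assay on HEK-293T cells for inhibition of diacylglycerol lipase-alpha (Homo sapiens), read by colorimetric assay (on this read-out higher numbers stand for weaker inhibition and lower numbers for stronger inhibition), compound 1 gives > 10000 nM, which is a limit of the assay rather than a number. Compound 2 likewise gives > 10000 nM in this assay, again a limit. Among the compounds with values here, the single measured step, a step that the two limits leave unreadable from compound 1 to compound 2, therefore cannot be read in size or direction, and the evidence amounts to the limit of > 10000 nM in this assay, at which 2 of the 2 values shown sit.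

Within the data shown here, compound 2 thus stands at the same limit as the only other measured compound; nothing in the numbers sets the two apart.

The next compound, compound 3, is `Cc1ccc(-c2cnc(C(=O)CCCCCCc3ccccc3)o2)nc1`. It differs from compound 2 by 5-methylpyridin-2-yl in place of 4-fluorophenyl on an aromatic carbon. Among the measured compounds shown here, no measured step bears readably on this change; the one step available, from compound 1 to compound 2, shows only two limits. With both shown values at a limit, the estimate for compound 3 is a value expected to remain near or beyond that limit, with no direction readable, so that a step that the limit leaves unreadable from compound 2 to compound 3 is expected to be no step beyond the scatter. Compound 3 is therefore estimated at 15000 nM, within 3000 nM to 60000 nM.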

Compound 3, half-maximal inhibitory concentration: > 10000 nM
Compound 3: only a limit was reported; the forecaster's own chance of this, stated with the estimate: 70%; the middle value lies beyond the limit too.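

In this assay compound 3 gives > 10000 nM, which is again a limit and not a number. Within the data shown here, no step among compound 1, compound 2 and compound 3 can therefore be read, in size or direction. The compounds shown leave open whether any group at this place on the shared core would give a measurable value, and the evidence stays as it was: the limit of > 10000 nM in this assay, at which 3 of the 3 values shown sit.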